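The source may hold more compounds than are shown below. What is called first, only, known or untested is meant among the compounds shown, and "the series" means these compounds.

Measured compounds, with the largest response reached in a functional assay on CHO-K1 cells with Glucose-dependent insulinotropic receptor (Homo sapiens) as the target, read by a luciferase reporter, with a stated time of 5 h; a lower number here means a smaller maximal response, a higher number a larger maximal response:
compound 1, `CC(C)(C)OC(=O)N1CCC(Oc2ncnc3c2CCN3c2ccc(S(C)(=O)=O)cc2F)CC1`: 139%
compound 2, `COC(=O)N1CCC(Oc2ncnc3c2CCN3c2ccc(S(C)(=O)=O)cc2F)CC1`: 119%
compound 3, `CCCCOC(=O)N1CCC(Oc2ncnc3c2CCN3c2ccc(S(C)(=O)=O)cc2F)CC1`: 131%

Compound 3 stands second highest of the three numbers in this assay. Its nearest neighbour is compound 1, and the difference a number 8 percentage points lower from compound 1 to compound 3 (within the scatter) lies within the scatter; the furthest is compound 2, where a number 12 percentage points higher from compound 2 to compound 3 (beyond the scatter) is beyond the scatter, though modest.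

Compound 4, `COCCOC(=O)N1CCC(Oc2ncnc3c2CCN3c2ccc(S(C)(=O)=O)cc2F)CC1`, is not yet measured in this assay. It differs from compound 3 by methoxy in place of ethyl on a saturated chain carbon, two bonds along the chain from an oxygen next to a carbonyl group. For the measured compounds named here, the steps that bear on this are the ones that alter the group on the oxygen next to a carbonyl group: a number 20 percentage points lower from compound 1 to compound 2 (beyond the scatter) and a number 12 percentage points higher from compound 2 to compound 3 (beyond the scatter) are both modest and beyond the scatter, while a number 8 percentage points lower from compound 1 to compound 3 (within the scatter) is within it. The whole spread across these three variants is small, and nothing measured here shows what an oxygen placed in that chain does. The step of a number 6 percentage points lower from compound 3 to compound 4 (within the scatter) is therefore expected to be small. A slight downward lean is expected because compound 2 with the shortest chain gives 119%, the lowest of the three. Compound 4 is estimated at 125%, with a range from 108% to 142%.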

Compound 4, largest response reached (reported as percent of maximum), in percent of the reference or control that the assay uses: 86%
Beside the measured number, compound 4's estimate is 39 percentage points above it; the measured number lies below the stated range.
By their numbers in this assay, from the lowest: compound 4; then compound 2; then compounds 3 and 1 (each within the scatter of the next).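

In this assay the group on the oxygen next to a carbonyl group proves far more sensitive than the three alkyl variants suggested: methoxy in place of ethyl on a saturated chain carbon, two bonds along the chain from that oxygen, gives a number 45 percentage points lower from compound 3 to compound 4 (beyond the scatter) and leaves the count of heavy atoms in the exchanged group unchanged. The loss also stands against the other two variants, with a number 33 percentage points lower from compound 2 to compound 4 (beyond the scatter) and a number 53 percentage points lower from compound 1 to compound 4 (beyond the scatter), so the 2-methoxyethyl group falls clear of methyl, butyl and tert-butyl alike, and chain length among the alkyl groups does not predict it. Nothing available here accounts for this drop.

Still open, going by these compounds, is whether the drop belongs to the chain oxygen as such or to its place in the chain, a question on which a 3-methoxypropyl, 2-hydroxyethyl or 2-aminoethyl group on the same oxygen would bear. Also open, on these data alone, is whether the same exchange would cost as much on a different aryl group at the far end of the shared core.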